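A few compounds are considered here, and "the series" means these few. Any claim that something is new, unique, unknown or untested is made for them only; others in the source may bear on it.

Three compounds that share one core have been examined in a functional assay on L1210 cells (Mus musculus) for cytotoxicity, read by cell counting, with a stated time of 2 days; on this read-out higher numbers stand for weaker inhibition and lower numbers for stronger inhibition. Compound 1 `C=C(Br)C(=O)Nc1ccc(/C=C2\SC(=O)N(Cc3ccc(Cl)cc3)C2=O)cc1` gives 3400 nM. Compound 2 `C=C(Br)C(=O)Nc1ccc(/C=C2\SC(=O)N(Cc3ccc(F)cc3)C2=O)cc1` carries the change fluoro in place of chloro on an aromatic carbon and gives 2200 nM, so that a 1.5-fold lower number from compound 1 to compound 2 (0.19 log units; within the scatter). Compound 3 `C=C(Br)C(=O)Nc1ccc(/C=C2\SC(=O)N(Cc3cccc(Cl)c3)C2=O)cc1` gives 3400 nM; its core differs from that of compound 1 by 3-chlorophenyl in place of 4-chlorophenyl on a saturated chain carbon bound to an amide-type nitrogen in a ring, and no change at the digits printed from compound 1 to compound 3 (within the scatter). Between the remaining pair, a 1.5-fold higher number from compound 2 to compound 3 (0.19 log units; within the scatter). All three numbers therefore sit close together, and none of the compounds can be called stronger or weaker than another on this evidence.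

Compound 4 `C=C(Br)C(=O)Nc1ccc(/C=C2\SC(=O)N(Cc3cccc(F)c3)C2=O)cc1` has not yet been measured in this assay. It differs from compound 3 by fluoro in place of chloro on an aromatic carbon. This is the same kind of change that turns compound 1 into compound 2, but not the same change: in the earlier pair the exchanged halogen sits para to a large group, whereas here it sits meta to a large group. Within the data shown here, the one direct precedent, the step of a 1.5-fold lower number from compound 1 to compound 2 (0.19 log units; within the scatter), stayed within the scatter, and the move of the chloro from the para to the meta position, no change at the digits printed from compound 1 to compound 3 (within the scatter), likewise left the number unchanged. On that basis the step from compound 3 to compound 4 is expected to be a 1.4-fold lower number from compound 3 to compound 4 (0.15 log units; within the scatter). Compound 4 is accordingly estimated at 2400 nM. For compound 4 the likely range is expected to run from 1200 nM to 4800 nM.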

Compound 4, half-maximal inhibitory concentration: 1200 nM
Compound 4: middle estimate off by 2.0-fold (0.30 log units), on the high side; the range from low to high includes it.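

Exchanging chloro for fluoro gives a 2.8-fold lower number from compound 3 to compound 4 (0.45 log units; beyond the scatter) in this assay, and the two cases of this exchange can be set side by side, with the gap between them no larger than ordinary measurement scatter would allow: the same change on two cores in this assay, a 1.5-fold lower number (0.19 log units; within the scatter) from compound 1 to compound 2 and a 2.8-fold lower number (0.45 log units; beyond the scatter) from compound 3 to compound 4, 1.8-fold (0.26 log units) apart, within the scatter of two such steps The change therefore carries from the core of compound 1 to the core of compound 3 in the limited sense that the two steps cannot be told apart, but this does not show that the step is truly larger on one core, and two pairs make no general rule for this series. The other new steps need the same care: there is a 2.8-fold lower number from compound 1 to compound 4 (0.45 log units; beyond the scatter), which is a modest step, whereas a 1.8-fold lower number from compound 2 to compound 4 (0.26 log units; within the scatter) stays within the scatter, so compound 2 and compound 4 cannot be separated on this evidence.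

The compounds shown carry only chloro or fluoro on the aromatic ring, so it remains open how the number would respond to a methoxy group, a trifluoromethyl group or an amine there. As far as these compounds go, it also remains open whether the fluoro-for-chloro step would hold with a longer chain leading to that ring.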